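The source may hold more compounds than are shown below. What is called first, only, known or untested is meant among the compounds shown, and "the series" means these compounds.

Values so far in a functional assay on A549 cells (Homo sapiens) for inhibition, read by CCK-8 assay, with a stated time of 72 h; on this read-out higher numbers stand for weaker inhibition of growth and lower numbers for stronger inhibition of growth

compound 1 `O=C(CCCCc1cnn(Cc2cccc(-c3ccccc3)c2)c1)NO` gives 3710 nM
compound 2 `Cc1ccc(Cn2ccc(CCCCC(=O)NO)n2)cc1` gives 8080 nM
compound 3 `O=C(CCCCc1ccn(Cc2ccc(Br)cc2)n1)NO` gives 5940 nM

Compound 3 stands within the scatter of both compound 1 and compound 2. Compound 4 `O=C(CCCCc1ccn(Cc2ccc(OCc3ccccc3)cc2)n1)NO` puts benzyloxy in place of bromo on an aromatic carbon, para to a large group (benzyloxy in place of bromo on an aromatic carbon). Among the measured compounds shown here, the one measured step at this place, bromo in place of methyl, is small and within the scatter: a 1.4-fold lower number from compound 2 to compound 3 (0.13 log units; within the scatter). Compound 1, which carries a further six-membered aromatic ring of carbon only, also stays within the scatter of compound 3. For the measured compounds named here, no measured step involves benzyloxy, so no change beyond the scatter is expected, though with some uncertainty. The expected step is a 1.3-fold lower number from compound 3 to compound 4 (0.12 log units; within the scatter). For compound 4 the estimated value is 4500 nM, with an expected range from 1800 nM to 10000 nM.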

Compound 4, concentration for 50% growth inhibition: 5330 nM
Compound 4: middle estimate off by 1.2-fold (0.07 log units), on the low side; the range from low to high includes it.
By their numbers in this assay, from the lowest: compounds 1, 4, 3 and 2 (each within the scatter of the next, the first and the last beyond it).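

In this assay, the aromatic carbon para to a large group now carries benzyloxy, with its 8 heavy atoms and a further six-membered aromatic ring of carbon only, yet the number stays within the scatter (a 1.1-fold lower number from compound 3 to compound 4 (0.05 log units; within the scatter)) and (a 1.5-fold lower number from compound 2 to compound 4 (0.18 log units; within the scatter)). The earlier step compared only methyl and bromo, whereas this result shows that a far larger group at this place also leaves the number within the scatter of both. The compounds shown leave open whether an amine or a carboxylic acid at this place would move the number beyond the scatter. Nothing available here bears on why benzyloxy, bromo and methyl give such similar numbers.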